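The compounds below may be only part of what the source reports. "The series", "measured", "known", "first", "only" and "open" are said of these compounds alone.

Measured so far:
compound 1, `COc1ccc(C(=O)/C=C/c2nc3ccccc3cc2-c2ccc(OC)cc2)cc1`, 7380 nM
compound 2, `COc1ccc(-c2cc3ccccc3nc2/C=C/C(=O)c2ccccn2)cc1`, 810 nM

In a functional assay on MCF7 cells (Homo sapiens) for antiproliferative activity, read by XTT assay, with a stated time of 72 h (a higher number here means a weaker inhibitor, a lower number a stronger inhibitor), compound 2 gives the lower of the two numbers recorded; its nearest neighbour is compound 1, and the distance between them is told by a 9.1-fold lower number from compound 1 to compound 2 (0.96 log units; beyond the scatter), a step beyond the scatter. Compound 3, `COc1ccc(-c2cc3ccccc3nc2/C=C/C(=O)c2ccsc2)cc1`, differs from compound 2 in one place: thiophen-3-yl in place of pyridin-2-yl on a carbonyl carbon. Within the data shown here, only one measured step bears on this change, the exchange of the group on the carbonyl carbon from compound 1 to compound 2, which was of modest size. That step shows that the ring on the carbonyl carbon matters in this assay, but it does not show what a five-membered ring does there. The replacement of pyridin-2-yl by thiophen-3-yl is therefore expected to move the number upward, by an amount close to a 3.1-fold higher number from compound 2 to compound 3 (0.49 log units; beyond the scatter), that is toward a weaker inhibitor. For compound 3 the estimate in this assay is 2500 nM, with a range from 700 nM to 9000 nM.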

Compound 3, half-maximal inhibitory concentration: 6010 nM
Estimate against measurement, compound 3: 2.4-fold (0.38 log units) below; low and high end bracket the measured number.
By their numbers in this assay, from the lowest: compound 2; then compounds 3 and 1 (each within the scatter of the next).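

In this assay, the advantage seen with pyridin-2-yl on the carbonyl carbon does not extend to every aromatic ring with one hetero atom: thiophen-3-yl gives a 7.4-fold higher number from compound 2 to compound 3 (0.87 log units; beyond the scatter) and so loses that advantage. Thiophen-3-yl and 4-methoxyphenyl cannot be told apart at this position, as a 1.2-fold lower number from compound 1 to compound 3 (0.09 log units; within the scatter) lies within the scatter, so among these three groups only pyridin-2-yl stands out. Nothing here explains why pyridin-2-yl differs from the other two groups.

The compounds shown leave open whether this advantage requires pyridin-2-yl specifically or would also appear with pyridin-3-yl or pyridin-4-yl. They also leave open how thiophen-2-yl, furan-2-yl or unsubstituted phenyl would read on the same carbonyl carbon.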